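This account rests on a few compounds, and the source may have more. Where it says the series, first, only, none or still open, it means among the compounds named here.

Of the compounds shown here, two on a shared core have been measured so far, and they differ only in the difluorophenyl group they carry. In a functional assay on HL-60 cells (Homo sapiens) for cytotoxicity, read by CellTiter-Blue, with a stated time of 48 h (on this read-out higher numbers stand for weaker inhibition and lower numbers for stronger inhibition), compound 1 (`CCOC(=O)CC1C(C(=O)OCC)=C(N)Oc2ccc(-c3ccc(F)cc3F)cc21`) gives 76600 nM, while compound 2 (`CCOC(=O)CC1C(C(=O)OCC)=C(N)Oc2ccc(-c3cc(F)cc(F)c3)cc21`) gives 35900 nM, the lower of the two numbers. Going by the values given here, the only measured step is a 2.1-fold lower number from compound 1 to compound 2 (0.33 log units; beyond the scatter). The next compound, compound 3 (`CCOC(=O)CC1C(C(=O)OCC)=C(N)Oc2ccc(-c3ccncc3)cc21`), has not yet been measured, and it departs from compound 2 in the same place: pyridin-4-yl in place of 3,5-difluorophenyl on an aromatic carbon. Among the compounds with values here, the measured step bears on this change only loosely, since it exchanges one difluorophenyl group for another, and no measured compound has a hetero atom in this ring. It does show that a change at this place has moved the number modestly, so a step of similar modest size is expected in this assay. A slight lean towards a higher number is expected, as compound 2 at 35900 nM is already the lower of the two, though the direction remains uncertain. The expected move is a 1.4-fold higher number from compound 2 to compound 3 (0.14 log units; within the scatter). For compound 3 the estimated value is 50000 nM, with an expected range from 20000 nM to 120000 nM.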

Compound 3, half-maximal inhibitory concentration: 10200 nM
Beside the measured number, compound 3's estimate is 4.9-fold (0.69 log units) above it, and the stated range ends above it.
By their numbers in this assay, from the lowest: compound 3; then compound 2; then compound 1.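

Changing the ring at this position to one that holds a hetero atom moves the number further than exchanging one difluorophenyl group for the other: pyridin-4-yl in place of 3,5-difluorophenyl brings a 3.5-fold lower number from compound 2 to compound 3 (0.55 log units; beyond the scatter) in this assay and pyridin-4-yl in place of 2,4-difluorophenyl brings a 7.5-fold lower number from compound 1 to compound 3 (0.88 log units; beyond the scatter) on the same read-out. Both steps lie beyond the scatter and run the same way, so compound 3 has the lowest number of the three, and this position tolerates a ring without fluorine that has one hydrogen-bond acceptor by count. Nothing available explains why the number falls with this change.

The compounds shown leave open whether the lower number follows the ring nitrogen itself, its place in the ring, or simply the loss of the two fluorines, which pyridin-3-yl, pyridin-2-yl and plain phenyl at this position would help to separate. They also leave open whether a group that is not an aromatic ring, such as morpholine or a carboxylic acid, would be accepted here, and whether the step would hold with other esters on the shared core.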